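Dropping a methyl from the aryl amide of compound 1

The compounds below may be only part of what the source reports. "The series", "measured", "known", "first", "only" and "open" are said of these compounds alone.

Compound 1 `COc1cc2c(Nc3nc4ccc(C(=O)Nc5c(C)cc(C)cc5C)cc4s3)ncnc2cc1OCCCN1CCC(C)CC1` has the lower of the two numbers measured in a functional assay on K562 cells (Homo sapiens) for cytotoxicity, read by WST assay, with a stated time of 72 h; on this read-out higher numbers stand for weaker inhibition and lower numbers for stronger inhibition: compound 1 gives 5900 nM, while compound 2 `COc1cc2c(Nc3nc4ccc(C(=O)Nc5c(C)cccc5C)cc4s3)ncnc2cc1OCCCN1CCCCC1C` gives 12300 nM, a gap beyond the scatter; compound 2 differs from compound 1 in two places, so no single change explains it. Compound 3 `COc1cc2c(Nc3nc4ccc(C(=O)Nc5c(C)cccc5C)cc4s3)ncnc2cc1OCCCN1CCC(C)CC1` is compound 1 with one change: hydrogen in place of methyl on an aromatic carbon. Going by the values given here, no step measuring this change alone exists. Compound 3 is expected to be somewhat weaker, a step of a 1.4-fold higher number from compound 1 to compound 3 (0.16 log units; within the scatter), so compound 3 is estimated at 8500 nM, between 3500 nM and 21000 nM.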

Compound 3, half-maximal inhibitory concentration: 15800 nM
Estimate against measurement, compound 3: 1.9-fold (0.27 log units) below, within the range that was stated.
By their numbers in this assay, from the lowest: compound 1; then compounds 2 and 3 (each within the scatter of the next).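

Going from 2,4,6-trimethylphenyl to 2,6-dimethylphenyl on the amide gives a 2.7-fold higher number from compound 1 to compound 3 (0.43 log units; beyond the scatter) in this assay and shows that this one methyl, on its own, makes a real difference to the read-out. With 2,6-dimethylphenyl held fixed, the swap of methylpiperidine isomers gives a 1.3-fold higher number from compound 2 to compound 3 (0.11 log units; within the scatter) and leaves 4-methylpiperidin-1-yl and 2-methylpiperidin-1-yl indistinguishable here. Nothing available explains the effect of the methyl. From the compounds shown here alone, whether ethyl, methoxy or chlorine in that place would match methyl remains open, as does the effect of an unsubstituted piperidine at the chain end.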